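This account rests on a few compounds, and the source may have more. Where it says the series, first, only, none or still open, it means among the compounds named here.

Among the compounds with values here, compound 2 `O=S(=O)(Nc1ccc(-c2nc3ccccc3o2)cc1)c1cccc(Cl)c1` is the one compound here with a measured number. In an assay on cells for inhibition of HSP60/HSP10 (Homo sapiens), with a stated time of 60 min (on this read-out lower numbers stand for stronger inhibition and higher numbers for weaker inhibition), compound 2 gives 54000 nM. Compound 1 `Cc1ccccc1S(=O)(=O)Nc1ccc2oc(-c3ccccc3)nc2c1` gives only > 100000 nM, which is a limit of the assay rather than a number, namely (the limit of > 100000 nM in this assay, at which 1 of the 2 values shown sits). Compound 3 `COc1cccc(S(=O)(=O)Nc2ccc(-c3nc4ccccc4o3)cc2)c1` is compound 2 with a single change: methoxy in place of chloro on an aromatic carbon. Within the data shown here, with no step between measured compounds to lean on, the expectation for this assay is a step no larger than the usual scatter, in no firm direction. The expected step is a 1.1-fold lower number from compound 2 to compound 3 (0.03 log units; within the scatter). Compound 3 is therefore expected near 50000 nM, somewhere from 15000 nM to 150000 nM.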

Compound 3, half-maximal inhibitory concentration: 80000 nM
Beside the measured number, compound 3's estimate is 1.6-fold (0.20 log units) below it; the range from low to high includes it.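

In this assay methoxy in place of chloro gives a 1.5-fold higher number from compound 2 to compound 3 (0.17 log units; within the scatter) and so this change, at a place meta to a large group, makes no clear difference. The hydrogen-bond acceptor that enters with the methoxy group therefore brings no clear gain on this read-out. Nothing shown here explains the small step. Going by these compounds, whether an amine, a carboxylic acid or a longer chain at this position would give a clearly lower number stays open.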